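This account rests on a few compounds, and the source may have more. Where it says the series, first, only, none or still open, it means among the compounds named here.

Measured so far in a functional assay on SK-MES-1 cells (Homo sapiens) for cytotoxicity, read by MTT assay, with a stated time of 96 h; on this read-out lower numbers stand for an effect already at smaller amounts and higher numbers for an effect only at larger amounts of compound:
- compound 1 `CCOC(=O)/C(=C/c1c(-c2ccccc2)[nH]c2ccccc12)C(=O)c1ccccc1`: > 100000 nM
- compound 2 `O=C(C(=Cc1c(-c2ccccc2)[nH]c2ccccc12)C(=O)c1ccccc1)c1ccccc1`: > 100000 nM

Both entries are limits of the assay rather than numbers. Compound 1 gives > 100000 nM in this assay, a limit only. Compound 2 likewise returns > 100000 nM in this assay, again a limit. Compound 1 therefore stands at the limit of > 100000 nM in this assay, at which 2 of the 2 values shown sit; nothing in the series so far gives a number to place it against, and the two limits shown cannot be ordered.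

The next compound, compound 3 `CCOC(=O)/C(=C/c1c(-c2ccccc2)[nH]c2ccccc12)C(=O)c1ccc([N+](=O)[O-])cc1`, differs from compound 1 by nitro in place of hydrogen on an aromatic carbon. Going by the values given here, no measured step between compounds exists, so the size of the change going from compound 1 to compound 3 cannot be read from data. The expectation is that compound 3 stays near the limit, with no step beyond the scatter: the estimated step is a number no higher from compound 1 to compound 3 (the limit leaves the size open). For compound 3 in this assay the expected value is 100000 nM, within 30000 nM to 300000 nM, and most likely reported once more as a limit.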

Compound 3, half-maximal effective concentration: 19000 nM
Beside the measured number, compound 3's estimate is 5.3-fold (0.72 log units) above it; measured number below the stated range.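

In this assay, nitro in place of hydrogen on an aromatic carbon, para to a large group, takes the series off the limit, giving an at least 5.2-fold lower number from compound 1 to compound 3 (0.72 log units; beyond the scatter). The earlier compounds shown here could not show this: a single substitution on the benzoyl ring of compound 1 is enough to give a measurable number in this read-out. Compound 3 is the only compound with such a number, and the others remain limits: the limit of > 100000 nM in this assay, at which 2 of the 3 values shown sit.

On these data alone, it remains open whether an amine, a carboxylic acid or a chlorine atom at the same carbon would give a step like that of nitro, or whether nitro at another carbon of this ring would do so. As far as these compounds go, the same nitro substitution on compound 2 also remains open.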